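A few compounds are considered here, and "the series" means these few. Any claim that something is new, unique, unknown or untested is made for them only; others in the source may bear on it.

In a functional assay on MCF7 cells (Homo sapiens) for antiproliferative activity, read by MTT assay, with a stated time of 72 h (a higher number here means a weaker inhibitor, a lower number a stronger inhibitor), compound 1 `CCCSc1nc(N/N=C(\C)c2ccccc2O)c2nnn(Cc3cccc(Cl)c3)c2n1` gives 39900 nM. Within the data shown here, that is the only plain number among the three measured compounds. Compound 2 `C#CCSc1nc(N/N=C/c2ccc(N(C)C)cc2)c2nnn(Cc3ccccc3)c2n1` reaches the limit of the assay, > 64000 nM, and returns no number. Compound 3 `CCCSc1nc(N/N=C/c2cccc(Cl)c2)c2nnn(Cc3ccccc3)c2n1` likewise stops at the limit, > 64000 nM, not a number. Most of what is known here is therefore (the limit of > 64000 nM in this assay, at which 2 of the 3 values shown sit), which leaves compound 1 as the one compound for which this assay gave a value to build on. Compound 4 `CCCSc1nc(N/N=C(\C)c2ccccc2O)c2nnn(Cc3ccc(O)cc3)c2n1` has not yet been measured. It differs from compound 1 in one place: 4-hydroxyphenyl in place of 3-chlorophenyl on a saturated chain carbon bound to an aromatic nitrogen. Among the measured compounds shown here, no two of the measured compounds differ in a single place, so no measured step shows how much a swap of this kind moves the result in this assay. With so little to go on, the change is expected to shift the result only slightly, if at all: a 1.1-fold higher number from compound 1 to compound 4 (0.05 log units; within the scatter), within the usual scatter or a little toward weaker inhibition. Compound 4 is estimated at 45000 nM, with a range from 18000 nM to 110000 nM.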

Compound 4, half-maximal inhibitory concentration: 9520 nM
Estimate against measurement, compound 4: 4.7-fold (0.67 log units) above; the measured number lies below the stated range.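

Among these compounds, this is the first measured step at this position in this assay: with 4-hydroxyphenyl in place of 3-chlorophenyl on a saturated chain carbon bound to an aromatic nitrogen, there is a 4.2-fold lower number from compound 1 to compound 4 (0.62 log units; beyond the scatter). The rest of the molecule is the same in both compounds, so the position can move the result, and in the direction of stronger inhibition for this swap. The swap alters both the substituent and where it sits on the ring, and nothing measured here separates those two changes or explains the gain.

Groups such as 4-chlorophenyl, 3-hydroxyphenyl or 4-methoxyphenyl at this place would begin to pull those changes apart. Compounds 2 and 3 differ from compound 1 in more than one place, and much of what is shown remains a limit and not a number: the limit of > 64000 nM in this assay, at which 2 of the 4 values shown sit.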